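A few compounds are considered here, and "the series" means these few. Any claim that something is new, unique, unknown or untested is made for them only; others in the source may bear on it.

Measured compounds:
- compound 1, `Oc1ccc(O)c(-c2cc(-c3ccc(Cl)cc3)nn2-c2ccccc2)c1`, 5750 nM
- compound 2, `CC(=O)NS(=O)(=O)c1ccc(-n2nc(-c3ccccc3)cc2-c2cc(O)ccc2O)cc1`, 78600 nM
- compound 3, `O=C1C=CC(=O)C(c2cc(-c3ccc(Cl)cc3)nn2-c2ccccc2)=C1`, 42400 nM

Three compounds built on related cores were tested in a functional assay on cells (Cancer cell lines, Homo sapiens) for cytotoxicity, read by sulforhodamine B assay, with a stated time of 48 h; on this read-out higher numbers stand for weaker inhibition of growth and lower numbers for stronger inhibition of growth. Compound 1 gives 5750 nM, and compound 3, `O=C1C=CC(=O)C(c2cc(-c3ccc(Cl)cc3)nn2-c2ccccc2)=C1`, gives 42400 nM. The two are joined by one structural change, (a group of 8 heavy atoms (6 carbon, 2 oxygen; one six-membered non-aromatic ring of carbon only) in place of a group of 8 heavy atoms (6 carbon, 2 oxygen; one six-membered aromatic ring of carbon only), on an aromatic carbon), and that change made a step of a 7.4-fold higher number from compound 1 to compound 3 (0.87 log units; beyond the scatter). Compound 2, `CC(=O)NS(=O)(=O)c1ccc(-n2nc(-c3ccccc3)cc2-c2cc(O)ccc2O)cc1`, gives 78600 nM in this assay; how its core differs from that of compound 1 is not broken down here.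

The unmeasured compound 4, `CC(=O)NS(=O)(=O)c1ccc(-n2nc(-c3ccccc3)cc2C2=CC(=O)C=CC2=O)cc1`, arises from compound 2 through the same kind of change: a group of 8 heavy atoms (6 carbon, 2 oxygen; one six-membered non-aromatic ring of carbon only) in place of a group of 8 heavy atoms (6 carbon, 2 oxygen; one six-membered aromatic ring of carbon only), on an aromatic carbon. Around the place the two cases differ in what the neighbouring ring atoms carry: in compound 1 the ring carbon next to the place bears a phenyl group and the one two ring bonds away bears a 4-chlorophenyl group, whereas in compound 2 the neighbouring ring atom bears a large group and the one two ring bonds away bears a phenyl group.

Among the compounds with values here, the only precedent is the step seen from compound 1 to compound 3, a 7.4-fold higher number from compound 1 to compound 3 (0.87 log units; beyond the scatter), and on that basis compound 4 is expected to show a step of a 4.5-fold higher number from compound 2 to compound 4 (0.65 log units; beyond the scatter) from compound 2. Because compound 2 already gives 78600 nM, a weak number, the result for compound 4 may well fall outside the range the assay reports as a number. The estimate for compound 4 is 350000 nM, expected to lie between 90000 nM and 1500000 nM.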

Compound 4, concentration for 50% growth inhibition: 78400 nM
The estimate for compound 4 lay 4.5-fold (0.65 log units) above the measured number; measured number below the stated range.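

In this assay, putting the non-aromatic ring in place of the 2,5-dihydroxyphenyl group gave a step of a 1.0-fold lower number from compound 2 to compound 4 (0.00 log units; within the scatter), so on this core the change left the number within the scatter, unlike the clear step seen on the core of compound 1. Within the data shown here, the size of the step therefore did not carry from one core to the other, and the two cases differ by more than the scatter of two such steps: the same change on two cores in this assay, a 7.4-fold higher number (0.87 log units; beyond the scatter) from compound 1 to compound 3 and a 1.0-fold lower number (0.00 log units; within the scatter) from compound 2 to compound 4, 7.4-fold (0.87 log units) apart, beyond the scatter of two such steps This shows that the step seen on one core cannot be assumed to hold on the other, but with only two pairs it does not show which difference between the cores goes with the gap, as they differ in more than one place, and it gives no general rule for the series.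

The compounds shown leave open whether the gap follows the 4-chlorophenyl group, the large group or the two together, and how the step would run on a core carrying only one of them. Also open, as far as these compounds go, is how a methoxy group or an amine in place of the hydroxyl groups of the 2,5-dihydroxyphenyl group would read in this assay.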